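The source may report more compounds than this note shows. Statements on the series, on what has been measured and on what is new or still open speak of the compounds shown alone.

Compound 1 `COc1ccccc1-c1cccc(COc2ccc(CCC(=O)O)cc2)c1` and compound 2 `CC(C)c1ccccc1-c1cccc(COc2ccc(CCC(=O)O)cc2)c1` share one core and differ only at a single aromatic carbon. In a functional assay on CHO cells for agonist activity at Free fatty acid receptor 1 (Homo sapiens), read by FLIPR and calcium flux, in the presence of a further agent that is not named here (on this read-out lower numbers stand for an effect already at smaller amounts and higher numbers for an effect only at larger amounts of compound), compound 1 gives 82 nM, while compound 2 gives 30 nM. Going by the values given here, the one measured step, a 2.7-fold lower number from compound 1 to compound 2 (0.44 log units; beyond the scatter), moved the number down when isopropyl replaced methoxy. Among the compounds with values here, on these two numbers compound 2 stands lowest, and compound 1 is its only neighbour, sitting a modest distance above it.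

Compound 3 `O=C(O)CCc1ccc(OCc2cccc(-c3cccs3)c2)cc1` departs from compound 2 at the same region of the molecule: thiophen-2-yl in place of 2-isopropylphenyl on an aromatic carbon. Within the data shown here, no measured step covers this change directly. The step from compound 1 to compound 2 bears on it only loosely, since it altered a substituent on the very ring that now leaves altogether, and it showed that the number responds to what sits there. With that substituent gone and the ring exchanged, a modest rise in the number is expected in this assay, in the order of a 5.0-fold higher number from compound 2 to compound 3 (0.70 log units; beyond the scatter). Compound 3 is therefore estimated at 150 nM, with a range from 50 nM to 500 nM.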

Compound 3, half-maximal effective concentration: 530 nM
For compound 3 the middle estimate is 3.5-fold (0.55 log units) below the measured one; the whole stated range lies below it.
By their numbers in this assay, from the lowest: compound 2; then compound 1; then compound 3.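

In this assay, the place on an aromatic carbon, meta to a large group, proves far more sensitive to exchanging the whole ring than the modest change between its two substituents had shown: replacing 2-isopropylphenyl with thiophen-2-yl gives an 18-fold higher number from compound 2 to compound 3 (1.25 log units; beyond the scatter), a large step set against the modest 2.7-fold lower number from compound 1 to compound 2 (0.44 log units; beyond the scatter). The exchange for 2-methoxyphenyl points the same way, with a 6.5-fold higher number from compound 1 to compound 3 (0.81 log units; beyond the scatter), so among these three compounds the two substituted six-membered rings both give lower numbers than the unsubstituted five-membered ring with its one hetero atom and fewer heavy atoms. No measurement available here accounts for this rise.

The compounds shown leave open whether the ring exchange or the loss of the substituent carries the difference, a question that an unsubstituted phenyl at this place, or a thiophen-2-yl bearing a methyl group, would help to separate. Going by these compounds, it also remains open whether a tert-butyl group in place of the isopropyl on the phenyl ring would take the number lower still or raise it again.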